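The source may report more compounds than this note shows. Statements on the series, on what has been measured and on what is new or still open speak of the compounds shown alone.

Measured so far in a functional assay on HL-60 cells (Homo sapiens) for antiproliferative activity, read by XTT assay, with a stated time of 72 h; a lower number here means a stronger inhibitor, a higher number a weaker inhibitor:
Compound 1 `Cc1ncnc2c1c(-c1cccs1)cn2[C@@H]1O[C@H](CO)[C@@H](O)[C@H]1O` gives 5730 nM.
Compound 2 `COc1ncnc2c1c(-c1cccs1)cn2[C@@H]1O[C@H](CO)[C@@H](O)[C@H]1O` gives 80 nM.
Compound 3 `CNc1ncnc2c1c(-c1cccs1)cn2[C@@H]1O[C@H](CO)[C@@H](O)[C@H]1O` reaches only a limit of the assay, > 20000 nM.

Among the measured compounds shown here, of the two numbers, compound 1 stands highest; the one large step among the numbers is a 72-fold lower number from compound 1 to compound 2 (1.86 log units; beyond the scatter). The other steps run into the limit of > 20000 nM in this assay, at which 1 of the 3 values shown sits: an at least 3.4-fold higher number from compound 1 to compound 3 (0.54 log units; beyond the scatter) and an at least 250-fold higher number from compound 2 to compound 3 (2.39 log units; beyond the scatter).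

Compound 4 `Cc1ncnc2c1c(-c1ccsc1)cn2[C@@H]1O[C@H](CO)[C@@H](O)[C@H]1O` is next, reached from compound 1 by thiophen-3-yl in place of thiophen-2-yl on an aromatic carbon. For the measured compounds named here, every measured step so far changes the group on the other aromatic carbon of the shared core; none touches the thiophene. So no measured step bears on this change, and no step beyond the scatter is expected in this assay. Compound 4 is estimated at 5700 nM (1500 nM to 20000 nM), which means an expected 1.0-fold lower number from compound 1 to compound 4 (0.00 log units; within the scatter).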

Compound 4, half-maximal inhibitory concentration: 350 nM
The estimate for compound 4 lay 16-fold (1.21 log units) above the measured number; the measured number lies below the stated range.
By their numbers in this assay, from the lowest: compound 2; then compound 4; then compound 1. At a limit, above all of these: compound 3.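

In this assay, the point of attachment of the thiophene matters: thiophen-3-yl in place of thiophen-2-yl brings a 16-fold lower number from compound 1 to compound 4 (1.21 log units; beyond the scatter), although both groups have the same atoms and the same counts of donors and acceptors. Among the compounds shown here, the earlier compounds varied only the other aromatic carbon of the shared core, so this is the first sign that the thiophene position responds to a change. Nothing measured here accounts for this step. From the compounds shown here alone, it remains open whether the same exchange carries over to the methoxy group of compound 2. Going by these compounds, how this position responds to a phenyl or furan ring also remains open.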